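The source may report more compounds than this note shows. Statements on the series, on what has been measured and on what is new or still open speak of the compounds shown alone.

Compound 1 `C=Cc1cc(C(F)(F)F)cc(C(F)(F)F)c1` in an ADME assay for pharmacokinetics, read by LC-MS, in phosphate buffer, with a stated time of 72 h, at pH 7.4, tested at 250 uM (a higher number here means that the compound lasts longer, a lower number that the compound disappears faster), gives > 50 h, which is a limit of the assay.
Compound 2 `O=C(CBr)c1cc(C(F)(F)F)cc(C(F)(F)F)c1` in this assay gives < 0.017 h, also a limit of the assay.
Compound 3 `FC(F)(F)c1cc(C2CO2)cc(C(F)(F)F)c1` in this assay gives > 50 h, again a limit of the assay.

Compound 3 therefore sits at the upper end of what this assay reports, and it shares that position with compound 1 (the limit of > 50 h in this assay, at which 2 of the 3 values shown sit). Compound 4 `Fc1cc(C(F)(F)F)cc(C(F)(F)F)c1` differs from it by one change: fluoro in place of oxiran-2-yl on an aromatic carbon. Among the compounds with values here, two measured steps bear on this position. The step of an at least 2900-fold higher number from compound 2 to compound 3 (3.46 log units; beyond the scatter) is large, while the step that the two limits leave unreadable from compound 1 to compound 3 cannot be sized because both values are limits. With compound 3 already at the limit, the step that the limit leaves unreadable from compound 3 to compound 4 is expected to stay within the scatter. Compound 4 is estimated at 200 h, within 50 h to 1000 h.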

Compound 4, half-life: > 50 h
Compound 4: only a limit was reported; the forecaster's own chance of this, stated with the estimate: 95%; the middle value is on the limit's open side.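

In this assay compound 4 gives > 50 h, which is a limit of the assay. The change to fluoro gives an at least 2900-fold higher number from compound 2 to compound 4 (3.46 log units; beyond the scatter). Fluoro, with no ring, thus joins vinyl and oxiran-2-yl at the upper end of the read-out, while (bromomethyl)carbonyl stays alone at the lower end: the limit of > 50 h in this assay, at which 3 of the 4 values shown sit.

As far as these compounds go, the steps from compound 1 and from compound 3 to compound 4 cannot be read, and how these three compounds rank among themselves stays open. Also open, from the compounds shown here alone, is whether an amine or a carboxylic acid in this place would reach the same limit.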